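A few compounds are considered here, and "the series" means these few. Any claim that something is new, unique, unknown or untested is made for them only; others in the source may bear on it.

The measured compounds and their values in a functional assay on MKN-45 cells (Homo sapiens) for cytotoxicity, read by MTT assay, with a stated time of 72 h; a lower number here means a stronger inhibitor, a higher number a weaker inhibitor:
compound 1, `COc1cc(/C=N/NC(=O)Nc2ccc(Oc3ccnc(-c4nncn4CCN(C)C)c3)c(F)c2)cc(OC)c1OC`, gives 2900 nM;
compound 2, `CN(C)CCn1cnnc1-c1cc(Oc2ccc(NC(=O)N/N=C/c3ccc(O)c(O)c3)cc2F)ccn1`, gives 3240 nM;
compound 3, `CN(C)CCn1cnnc1-c1cc(Oc2ccc(NC(=O)N/N=C/c3cccc(Br)c3)cc2F)ccn1`, gives 450 nM.

Among these three, compound 3 stands lowest: the step is a 6.4-fold lower number from compound 1 to compound 3 (0.81 log units; beyond the scatter) and a 7.2-fold lower number from compound 2 to compound 3 (0.86 log units; beyond the scatter), while compound 1 and compound 2 differ only by a 1.1-fold higher number from compound 1 to compound 2 (0.05 log units; within the scatter). Compound 4, `Cc1cc(/C=N/NC(=O)Nc2ccc(Oc3ccnc(-c4nncn4CCN(C)C)c3)c(F)c2)cc(C)c1O`, is compound 3 with a single change: 4-hydroxy-3,5-dimethylphenyl in place of 3-bromophenyl on a carbon with a double bond to nitrogen. Going by the values given here, the steps that bear on this change are the two leading into compound 3, a 6.4-fold lower number from compound 1 to compound 3 (0.81 log units; beyond the scatter) and a 7.2-fold lower number from compound 2 to compound 3 (0.86 log units; beyond the scatter): in each, a ring bearing hydroxy or methoxy groups was exchanged for the 3-bromophenyl, and in each the number fell modestly. Compound 4 brings back a ring bearing a hydroxy group, closer in kind to the 3,4-dihydroxyphenyl of compound 2 than to the 3-bromophenyl of compound 3, so a step upward in this assay is expected, estimated at a 3.3-fold higher number from compound 3 to compound 4 (0.52 log units; beyond the scatter). Compound 4 is therefore expected to give about 1500 nM in this assay, within a range from 500 nM to 4500 nM.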

Compound 4, half-maximal inhibitory concentration: 1510 nM
Beside the measured number, compound 4's estimate is 1.0-fold (0.00 log units) below it; low and high end bracket the measured number.
By their numbers in this assay, from the lowest: compound 3; then compounds 4, 1 and 2 (each within the scatter of the next, the first and the last beyond it).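

In this assay, putting 4-hydroxy-3,5-dimethylphenyl in place of 3-bromophenyl on the carbon with a double bond to nitrogen raises the number (a 3.4-fold higher number from compound 3 to compound 4 (0.53 log units; beyond the scatter)), so a third ring bearing oxygen now stands above the bromine compound. Measured against the other two oxygen-bearing rings, the new ring gives a small drop from the 3,4-dihydroxyphenyl ring (a 2.1-fold lower number from compound 2 to compound 4 (0.33 log units; beyond the scatter)) and no difference beyond the scatter from the 3,4,5-trimethoxyphenyl ring (a 1.9-fold lower number from compound 1 to compound 4 (0.28 log units; within the scatter)). Hydroxy, methoxy and added methyl groups therefore adjust the number only slightly among these rings, and none of the three reaches the low number of compound 3.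

On these data alone, whether the bromine itself matters, or simply the lack of oxygen on the ring, stays open, and a plain phenyl or a 3-chlorophenyl ring at this place would help separate the two. Nothing measured here offers a reason for any of these differences.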